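Swapping Methyl for Fluoro on the Amide Aryl Group

The compounds below may be only part of what the source reports. "The series", "measured", "known", "first", "only" and "open" are said of these compounds alone.

Compound 1 `O=C(NCc1cccc(Cn2cnc3ccccc32)c1)c1cc2ccccc2o1` gives 413 nM in an assay for inhibition of Indoleamine 2,3-dioxygenase 1 (Homo sapiens), read by HPLC, with a stated time of 48 h; a lower number here means a stronger inhibitor, a higher number a weaker inhibitor.
Compound 2 `Cc1ccc2[nH]c(C(=O)NCc3cccc(Cn4cnc5ccccc54)c3)cc2c1` gives 636 nM in this assay.
Compound 3 `Cc1ccc(C(=O)NCc2cccc(Cn3cnc4ccccc43)c2)cc1` gives 327 nM in this assay.

The three measured compounds share one core and differ only in the aryl group attached to the carbonyl. Compound 3 has the lowest number of the three, but its gaps to the others are small: the step of a 1.3-fold lower number from compound 1 to compound 3 (0.10 log units; within the scatter) and the step of a 1.9-fold lower number from compound 2 to compound 3 (0.29 log units; within the scatter) both lie within the scatter, as does the step of a 1.5-fold higher number from compound 1 to compound 2 (0.19 log units; within the scatter). On these numbers, none of the three can be called the stronger inhibitor.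

Compound 4 `O=C(NCc1cccc(Cn2cnc3ccccc32)c1)c1ccc(F)cc1` differs from compound 3 by fluoro in place of methyl on an aromatic carbon of the ring on the carbonyl. Among the compounds with values here, no measured step tries this exact swap; each of the three measured steps replaced the whole ring on the carbonyl, and each stayed within the scatter. A far smaller change, swapping one atom for another on that ring, is therefore expected to give no step beyond the scatter in this assay.

Compound 4 is expected to give about 350 nM in this assay, within the range 150 nM to 800 nM. The expected step is a 1.1-fold higher number from compound 3 to compound 4 (0.03 log units; within the scatter).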

Compound 4, half-maximal inhibitory concentration: 961 nM
Estimate against measurement, compound 4: 2.7-fold (0.44 log units) below; measured number outside the range, above it.
By their numbers in this assay, from the lowest: compounds 3, 1, 2 and 4 (each within the scatter of the next, the first and the last beyond it).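

Within the data shown here, at this place on the ring on the carbonyl, a change of one heavy atom is enough to leave the scatter: fluoro in place of methyl gives a 2.9-fold higher number from compound 3 to compound 4 (0.47 log units; beyond the scatter) in this assay and is the first single-atom swap in the set. Replacing the whole ring gives mixed results, with 4-fluorophenyl in place of 1-benzofuran-2-yl giving a 2.3-fold higher number from compound 1 to compound 4 (0.37 log units; beyond the scatter) while 4-fluorophenyl in place of 5-methyl-1H-indol-2-yl gives a 1.5-fold higher number from compound 2 to compound 4 (0.18 log units; within the scatter), so the size of a structural change does not track the size of the step in these four compounds. Nothing measured here explains why methyl and fluoro part ways at this place.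

On these data alone, only methyl and fluoro are seen at this place, so what chloro, methoxy, a nitrile or a plain hydrogen would give remains open, and with it whether the step reflects something gained with methyl or something lost with fluoro. As far as these compounds go, it is also open whether fluoro in place of the methyl of compound 2 would give a step of similar size on that different ring.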